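This account rests on a few compounds, and the source may have more. Where it says the series, first, only, none or still open, it means among the compounds named here.

Of the compounds shown here, three built on one shared core have been tested so far. Compound 1 `Cc1ccc(NC(=S)NC(=O)c2cn(-c3ccccc3)nc2-c2ccc(F)cc2)cc1` was examined in a functional assay on MCF7 cells (Homo sapiens) for inhibition, read by CCK-8 assay, with a stated time of 48 h (on this read-out lower numbers stand for stronger inhibition and higher numbers for weaker inhibition), and in it compound 1 gives 5440 nM. Compound 2 `Cc1ccc(NC(=S)NC(=O)c2cn(-c3ccccc3)nc2-c2ccc(Cl)cc2)cc1` differs from compound 1 by chloro in place of fluoro on an aromatic carbon; in this assay compound 2 gives 5980 nM, and the step is a 1.1-fold higher number from compound 1 to compound 2 (0.04 log units; within the scatter). Compound 3 `O=C(NC(=S)Nc1ccc(F)cc1)c1cn(-c2ccccc2)nc1-c1ccc(F)cc1` differs from compound 1 on a different ring, by fluoro in place of methyl on an aromatic carbon; in this assay compound 3 gives 5610 nM, and the step is a 1.0-fold higher number from compound 1 to compound 3 (0.01 log units; within the scatter). All three numbers sit close together, so none of these compounds can be set apart from the others.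

Compound 4 `O=C(NC(=S)Nc1ccc(F)cc1)c1cn(-c2ccccc2)nc1-c1ccc(Cl)cc1` has not yet been measured in this assay. It differs from compound 3 by chloro in place of fluoro on an aromatic carbon. This is the same change that leads from compound 1 to compound 2, made at the same place, on an aromatic carbon of a six-membered aromatic ring of carbon only, para to a large group, and it appears in both pairs. The two pairs stand on cores that differ only in the way already described for compound 1 and compound 3.

Because the step of a 1.1-fold higher number from compound 1 to compound 2 (0.04 log units; within the scatter) stayed within the usual scatter, the step from compound 3 to compound 4 is expected to be small as well, about a 1.1-fold higher number from compound 3 to compound 4 (0.04 log units; within the scatter). Compound 4 is therefore expected to give around 6200 nM, most likely somewhere between 3500 nM and 11000 nM.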

Compound 4, half-maximal inhibitory concentration: 5990 nM
Estimate against measurement, compound 4: 1.0-fold (0.01 log units) above, within the range that was stated.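

In this assay, going from 4-fluorophenyl to 4-chlorophenyl gives a 1.1-fold higher number from compound 3 to compound 4 (0.03 log units; within the scatter), and this step matches the earlier one: the same change on two cores in this assay, a 1.1-fold higher number (0.04 log units; within the scatter) from compound 1 to compound 2 and a 1.1-fold higher number (0.03 log units; within the scatter) from compound 3 to compound 4, 1.0-fold (0.01 log units) apart, within the scatter of two such steps The change of methyl to fluoro on the other ring gives a 1.0-fold higher number from compound 2 to compound 4 (0.00 log units; within the scatter), and it too matches its earlier counterpart: the same change on two cores in this assay, a 1.0-fold higher number (0.01 log units; within the scatter) from compound 1 to compound 3 and a 1.0-fold higher number (0.00 log units; within the scatter) from compound 2 to compound 4, 1.0-fold (0.01 log units) apart, within the scatter of two such steps So, across these four compounds, each of the two changes leaves the number within the scatter on both cores, and neither change can be told apart from no effect at all; this does not show that a change with a large, clearly readable effect would carry over from one core to the other, and it says nothing about why these numbers stay so close.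

The compounds shown leave open whether any change at these two places can move the number beyond the scatter, for example an amine, a carboxylic acid or a longer chain in place of the halogen or the methyl. Only such a larger step, seen on both cores, would put the carrying over of a change in this series to a real test.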